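The source may report more compounds than this note shows. Statements on the series, on what has been measured and on what is new or still open speak of the compounds shown alone.

Compound 1 `CC1(C)O[C@H]2O[C@H]([C@H](CCO)n3cnc4c(N)ncnc43)[C@H](OCc3ccccc3)[C@H]2O1`: 97100 nM
Compound 2 `CCOC(=O)C[C@@H]([C@H]1O[C@@H]2OC(C)(C)O[C@@H]2[C@H]1Oc1ccccc1N)n1cnc2c(N)ncnc21`: 89700 nM
Compound 3 `CC1(C)O[C@H]2O[C@H]([C@@H](CCO)n3cnc4c(N)ncnc43)[C@H](Oc3ccccc3[N+](=O)[O-])[C@H]2O1`: 51800 nM

Three compounds built on the shared core of compound 1 have been examined in an ADME assay on Vero cells (Chlorocebus sabaeus) for cytotoxicity, read by fluorescence and resazurin assay, with a stated time of 3 days; a lower number here means that less compound is tolerated, a higher number that more compound is tolerated. Among the three values, compound 1 gives the highest number. Its nearest neighbour is compound 2, whose value sits within the usual scatter of the measurement, and even compound 3, the furthest of the three from compound 1, remains within that scatter. On these numbers, therefore, none of the three can be set apart from the others, and no ordering among them is claimed.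

The next compound in the series is compound 4 `COC(=O)C[C@@H]([C@H]1O[C@@H]2OC(C)(C)O[C@@H]2[C@H]1OCc1ccccc1)n1cnc2c(N)ncnc21`, which has not yet been measured in this assay. It differs from compound 1 in one place: methoxycarbonyl in place of hydroxymethyl on a saturated chain carbon, two bonds along the chain from an aromatic nitrogen and a saturated ring carbon. Among the measured compounds no pair differs in only one place, so no measured step of this kind is available to guide the expectation. What the three values do show is that every change made so far has left the number within the scatter, and a result of that size is the plain expectation here as well. The step is expected to be a 1.2-fold lower number from compound 1 to compound 4 (0.08 log units; within the scatter), not beyond the scatter. Compound 4 is estimated at 80000 nM, with a range from 35000 nM to 180000 nM.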

Compound 4, half-maximal cytotoxic concentration: 68400 nM
Compound 4: middle estimate off by 1.2-fold (0.07 log units), on the high side, within the range that was stated.
By their numbers in this assay, from the lowest: compounds 3, 4, 2 and 1 (each within the scatter of the next).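

Going by these compounds alone, this is the first change that can be read in one place: in this assay, methoxycarbonyl in place of hydroxymethyl on a saturated chain carbon, two bonds along the chain from an aromatic nitrogen and a saturated ring carbon, gives a 1.4-fold lower number from compound 1 to compound 4 (0.15 log units; within the scatter), and that step stays within the scatter. At this position, then, the one hydrogen-bond donor of hydroxymethyl can be exchanged for a group with no such donor, more heavy atoms and a double bond outside aromatic rings, with no difference in this read-out that can be told from repeat measurement. Nothing measured here offers an explanation for this result.

The compounds shown leave open whether a carboxylic acid, an amide, an amine or a longer chain at this same place would also stay within the scatter of compound 1. They also leave open whether the same exchange would give a step of similar size on a core carrying a group other than the benzyloxy of compound 1.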